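This account rests on a few compounds, and the source may have more. Where it says the series, first, only, none or still open, it means among the compounds named here.

In a functional assay on DU-145 cells (Homo sapiens) for inhibition, read by sulforhodamine B assay, with a stated time of 48 h (a higher number here means a weaker inhibitor of growth, a lower number a stronger inhibitor of growth), compound 1 (`COc1cc(-c2nn(-c3cccc(NC(=O)Nc4ccc(Cl)c(Cl)c4)c3)cc2-c2ccncc2)ccc1Cl`) gives 1520 nM, and compound 2 (`COc1cc(-c2nn(-c3cccc(NC(=O)Nc4cccc(C(F)(F)F)c4)c3)cc2-c2ccncc2)ccc1Cl`) gives 1670 nM. These two numbers lie within the usual scatter of each other, so compound 2 stands level with compound 1 and neither can be called the stronger inhibitor.

Compound 3 (`COc1cc(-c2nn(-c3cccc(NC(=O)c4ccccc4)c3)cc2-c2ccncc2)ccc1Cl`) has not yet been measured. It differs from compound 2 in one place: phenyl in place of (3-(trifluoromethyl)phenyl)amino on a carbonyl carbon.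

Among the measured compounds shown here, only one measured step offers any guidance: a 1.1-fold higher number from compound 1 to compound 2 (0.04 log units; within the scatter). That step exchanged 3,4-dichlorophenyl for 3-(trifluoromethyl)phenyl and stayed within the scatter, but the amide-type nitrogen carrying that ring remained in place. For the measured compounds named here, compound 3 loses the nitrogen of the leaving group, so this step says little about the new change, and no measured pair shows such a change directly.

The expected step is a 1.8-fold higher number from compound 2 to compound 3 (0.25 log units; within the scatter), a cautious guess towards weaker growth inhibition with real doubt about its size. For compound 3 the estimated value is 3000 nM, with a likely range from 1000 nM to 10000 nM.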

Compound 3, concentration for 50% growth inhibition: 780 nM
For compound 3 the middle estimate is 3.8-fold (0.59 log units) above the measured one; measured number below the stated range.
By their numbers in this assay, from the lowest: compounds 3, 1 and 2 (each within the scatter of the next, the first and the last beyond it).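

Compound 3 removes the amino nitrogen of the urea-type link and the ring substituent together, whereas the earlier step changed only the substituents on the ring and kept that nitrogen. With phenyl on the carbonyl carbon, this assay shows a 2.1-fold lower number from compound 2 to compound 3 (0.33 log units; beyond the scatter), a modest gain in growth inhibition that lies just beyond the scatter. The matching comparison with the dichlorinated urea gives a 1.9-fold lower number from compound 1 to compound 3 (0.29 log units; within the scatter), which lies within the scatter, so compound 3 stands level with compound 1, and the evidence shows that this position tolerates the shorter amide link and the bare phenyl ring without any loss, rather than showing a general gain.

Nothing available explains the difference between compound 2 and compound 3. Since two things change at once, the effect of losing the amino nitrogen remains separate and unknown from that of losing the ring substituents, and a 3-(trifluoromethyl)phenyl group placed directly on the carbonyl carbon would be needed to tell them apart, while a cyclohexyl or methyl group there would test whether any aromatic ring is needed at all.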